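The source may report more compounds than this note shows. Statements on the series, on what has been measured and on what is new or still open speak of the compounds shown alone.

Compound 1 `CC(C)N(Cc1cccc(OCCCCCC(=O)O)c1)C(=O)c1ccc(-c2ccncc2)cc1` gives > 26000 nM in an ADME assay on BJ cells (Homo sapiens) for cytotoxicity, read by CellTiter-Glo and resazurin assay, with a stated time of 72 h; a higher number here means that more compound is needed for the effect, a lower number that less compound is needed; this value is a limit of the assay, not a number. Compound 2 `COc1cc(OC)cc(-c2ccc(C(=O)N(Cc3cccc(OCCCCCC(=O)O)c3)C(C)C)cc2)c1` gives > 26000 nM in this assay, again a limit. Compound 3 `CC(C)N(Cc1cccc(OCCCCCC(=O)O)c1)C(=O)c1ccc(-c2cccc(OC(F)(F)F)c2)cc1` gives > 26000 nM in this assay, also a limit.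

Compound 1 thus stands at a limit only, and all three values shown sit at the same point, as the limit of > 26000 nM in this assay, at which 3 of the 3 values shown sit, records. The steps a step that the two limits leave unreadable from compound 1 to compound 2, a step that the two limits leave unreadable from compound 1 to compound 3 and a step that the two limits leave unreadable from compound 2 to compound 3 cannot be read in size, so they say nothing about how the changed aromatic group matters. Compound 4 `CCOC(=O)CCCCCOc1cccc(CN(C(=O)c2ccc(-c3ccncc3)cc2)C(C)C)c1` differs from compound 1 by ethyl in place of hydrogen on an oxygen next to a carbonyl group. Within the data shown here, no measured step touches this oxygen, so nothing is known about its effect. All three measured compounds sit at the limit shown in the limit of > 26000 nM in this assay, at which 3 of the 3 values shown sit, and compound 4 is expected to sit there too, with a step of a number no higher from compound 1 to compound 4 (the limit leaves the size open). The estimate for compound 4 is 26000 nM, within 13000 nM to 60000 nM.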

Compound 4, half-maximal effective concentration: > 26000 nM
Compound 4: no number, only a limit (the forecaster's own chance of this, stated with the estimate: 80%); the middle value lies on the limit itself.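

The step between compound 1 and compound 4 cannot be read, since both compounds give only a limit in this assay: the limit of > 26000 nM in this assay, at which 4 of the 4 values shown sit.

The compounds shown leave open whether ethyl in place of hydrogen on this oxygen changes the concentration needed for the effect.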